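Bromo to nitro from compound 2 to compound 4

This account rests on a few compounds, and the source may have more. Where it says the series, first, only, none or still open, it means among the compounds named here.

Values in a functional assay on SF-268 cells (Homo sapiens) for inhibition, read by sulforhodamine B assay, with a stated time of 48 h (on this read-out higher numbers stand for weaker inhibition of growth and lower numbers for stronger inhibition of growth), so far:
compound 1 `N#CCC1=NN=C(c2ccc(Br)cc2)C(CC(=O)c2ccc(Br)cc2)O1` gives 16900 nM
compound 2 `N#CCC1=NN=C(c2ccc(Br)cc2)C(CC(=O)c2ccc([N+](=O)[O-])cc2)O1` gives 18500 nM
compound 3 `N#CCC(=O)N/N=C(/CBr)c1ccc([N+](=O)[O-])cc1` gives 14000 nM

Compound 2 lies within the scatter of both compound 1 and compound 3. Compound 4 `N#CCC1=NN=C(c2ccc([N+](=O)[O-])cc2)C(CC(=O)c2ccc([N+](=O)[O-])cc2)O1` differs from compound 2 by one change nitro in place of bromo on an aromatic carbon (nitro in place of bromo on an aromatic carbon, para to a large group). For the measured compounds named here, the only measured step of this kind is a 1.1-fold higher number from compound 1 to compound 2 (0.04 log units; within the scatter) (within the scatter), and it sits on the other aromatic ring bearing bromo in compound 1. On that single step, no shift beyond the scatter is expected in this assay for this change. The expected step is a 1.0-fold higher number from compound 2 to compound 4 (0.01 log units; within the scatter) (an estimate). For compound 4 the estimated value is 19000 nM (expected range 11000 nM to 32000 nM) in this read-out.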

Compound 4, concentration for 50% growth inhibition: 2000 nM
Compound 4: the middle estimate sits 9.5-fold (0.98 log units) above what was measured, and the stated range ends above it.
By their numbers in this assay, from the lowest: compound 4; then compounds 3, 1 and 2 (each within the scatter of the next).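

In this assay the change from 4-bromophenyl to 4-nitrophenyl on this ring gives a 9.3-fold lower number from compound 2 to compound 4 (0.97 log units; beyond the scatter) and so lies beyond the scatter. The same change on the other ring gives a 1.1-fold higher number from compound 1 to compound 2 (0.04 log units; within the scatter) and stays within the scatter, so across these two steps the outcome depends on which ring carries it. Compound 4 is the only compound shown with nitro on both rings.

As far as these compounds go, whether the step needs the nitro on the other ring stays open, as does the outcome with an amine or a carboxylic acid at this position. The cause of the step is also open, with no evidence on it at hand.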